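From a chlorophenyl to a dimethoxyphenyl hydrazone

This account rests on a few compounds, and the source may have more. Where it says the series, first, only, none or still open, it means among the compounds named here.

Three hydrazones share one core, and compound 2 `O=C(CSc1nnnn1-c1cccc2ccccc12)N/N=C/c1cccc(Cl)c1` is the only one of them for which an ADME assay on MT4 cells (Homo sapiens) for cytotoxicity, read by MTT assay (on this read-out lower numbers stand for higher toxicity in this test and higher numbers for lower toxicity in this test), returns a number: compound 2 gives 240000 nM. Compound 1 `O=C(CSc1nnnn1-c1cccc2ccccc12)N/N=C/c1ccco1` sits at a limit of this assay, > 330000 nM, and not at a number. Compound 3 `O=C(CSc1nnnn1-c1cccc2ccccc12)N/N=C/c1ccccc1F` likewise sits at a limit of this assay, >= 118000 nM. The step of an at least 1.3-fold lower number from compound 1 to compound 2 (0.13 log units; that floor lies within the scatter) is therefore read only against a floor. The steps a step that the two limits leave unreadable from compound 1 to compound 3 and a step that the limit leaves unreadable from compound 2 to compound 3 cannot be sized, since the limit of >= 118000 nM in this assay, at which 1 of the 3 values shown sits, hides the value of compound 3.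

Compound 4 `COc1ccc(/C=N/NC(=O)CSc2nnnn2-c2cccc3ccccc23)c(OC)c1` is not yet measured and differs from compound 2 in one place: 2,4-dimethoxyphenyl in place of 3-chlorophenyl on a carbon with a double bond to nitrogen. For the measured compounds named here, no measured step bears on this change. Going by the values given here, none of the three compounds carries a methoxy group, and the only change with a readable floor, an at least 1.3-fold lower number from compound 1 to compound 2 (0.13 log units; that floor lies within the scatter), lies within the scatter. He therefore expects no step beyond the scatter in this assay, with a 1.0-fold higher number from compound 2 to compound 4 (0.02 log units; within the scatter) as the expected step. His estimate for compound 4 is 250000 nM, between 100000 nM and 600000 nM, with a fair chance that this assay again reports only a limit, as it did for compound 1 at the limit of > 330000 nM in this assay, at which 1 of the 3 values shown sits.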

Compound 4, half-maximal cytotoxic concentration: 28300 nM
Compound 4: the middle estimate sits 8.8-fold (0.95 log units) above what was measured; the whole stated range lies above it.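

For the compounds shown here, at this position, on a carbon with a double bond to nitrogen, the group carried there proves able to move the read-out of this assay: 2,4-dimethoxyphenyl in place of 3-chlorophenyl gives an 8.5-fold lower number from compound 2 to compound 4 (0.93 log units; beyond the scatter), the only step with a number at both ends. The same group also gives an at least 4.1-fold lower number from compound 3 to compound 4 (0.62 log units; beyond the scatter) and an at least 11-fold lower number from compound 1 to compound 4 (1.06 log units; beyond the scatter), so compound 4 has the lowest number of the four, and on this read-out that stands for the highest toxicity in this test. Among furan-2-yl, 3-chlorophenyl and 2-fluorophenyl, nothing of the kind had appeared, since the one floor that could be read lay within the scatter and the other steps among them cannot be read.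

The compounds shown leave open whether both methoxy groups are needed for this drop or a single methoxy group on the phenyl ring would give it as well. They also leave open whether a hydroxyl, an amine or a carboxylic acid on that phenyl ring would lower the number in the same way.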